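The compounds below may be only part of what the source reports. "The series", "measured", "known", "first", "only" and "open" are said of these compounds alone.

Two members of the series have been measured in an assay for binding affinity to 17-beta-hydroxysteroid dehydrogenase type 1 (Homo sapiens), with a stated time of 20 min, tested at 1 uM; on this read-out higher numbers stand for more inhibition at the one concentration tested (going by the name of the read-out) and lower numbers for less inhibition. Compound 1 `CN(C(=O)c1ccccc1)c1cccc(-c2ccc(CO)cc2)c1` gives < 10% in this assay, a limit of the assay rather than a number. Compound 2 `O=C(Nc1cccc(-c2ccc(O)cc2)c1)c1ccccc1` likewise gives < 10% in this assay, again a limit and not a number. Among the compounds with values here, compound 2 thus stands at the floor of the measured set together with the only other value shown, since (the limit of < 10% in this assay, at which 2 of the 2 values shown sit).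

Compound 3 `CN(C(=O)c1ccccc1)c1cccc(-c2ccc(O)cc2)c1` is the next member to be measured in this assay. It differs from compound 2 in one place: methyl in place of hydrogen on an amide-type nitrogen. Within the data shown here, no step between measured compounds covers this change. Compound 1 carries the same methyl on the amide-type nitrogen and also rests at the limit, so no step beyond the scatter is expected in this assay. The expected step is a step that the limit leaves unreadable from compound 2 to compound 3. Compound 3 is expected to give 5% in this assay, within 0% to 15%, most likely reported again as a limit.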

Compound 3, a percentage reported as inhibition, at one concentration (the size of the read-out at that concentration, not a potency): < 10%
Compound 3: no number, only a limit; the forecaster's own chance of this, stated with the estimate: 80%; the middle value lies beyond the limit too.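

No step can be read among compound 1, compound 2 and compound 3 in this assay, as each value is a limit of the assay: the limit of < 10% in this assay, at which 3 of the 3 values shown sit.

The compounds shown leave open whether either single change, methyl for hydrogen or hydroxy for hydroxymethyl, alters inhibition at all.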